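Chalcone series: replacing a methoxyphenyl ring with a chlorophenyl ring

A few compounds are considered here, and "the series" means these few. Any claim that something is new, unique, unknown or untested is made for them only; others in the source may bear on it.

Measured compounds:
- compound 1 `COc1cccc(/C=C/C(=O)c2c(OC)cc(OC)cc2OC)c1`: 0.6%
- compound 2 `COc1cc(O)c(C(=O)/C=C/c2ccccc2OC)c(OC)c1`: 27%

In a functional assay on HCT-116 cells (Homo sapiens), read by fluorescence and BrdU incorporation, with a stated time of 48 h, tested at 25 uM (on this read-out higher numbers stand for a weaker effect at the one concentration tested and lower numbers for a stronger effect), compound 1 gives 0.6%, the lowest of the two numbers available. Among the compounds with values here, the nearest measured neighbour, compound 2, gives 27%, a number that lies well beyond the scatter from the one for compound 1. Within the data shown here, the two compounds differ in more than one place, so their values are read only side by side and no single step can be drawn between them.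

Compound 3 `COc1cc(OC)c(C(=O)/C=C/c2ccc(Cl)cc2)c(OC)c1` is not yet measured in this assay. It differs from compound 1 in one place:
4-chlorophenyl in place of 3-methoxyphenyl on a double-bonded chain carbon bound to a double-bonded chain carbon
The shared core of compound 1 is kept unchanged.

Because compound 1 gives 0.6%, the starting point is a small number, and the expectation for compound 3 is a number of similar size, with the expected step being a number 7.4 percentage points higher from compound 1 to compound 3 (within the scatter), a modest move towards a weaker effect that may stay within the scatter. Compound 3 is estimated at 8%, with a range from 0.5% to 45%.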

Compound 3, a percentage reported as activity, at one concentration (the size of the read-out at that concentration, not a potency): 0%
Estimate against measurement, compound 3: 8 percentage points above, and the stated range ends above it.
By their numbers in this assay, from the lowest: compounds 3 and 1 (each within the scatter of the next); then compound 2.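

In this assay, within the data shown here, 4-chlorophenyl in place of 3-methoxyphenyl on a double-bonded chain carbon bound to a double-bonded chain carbon gives a number 0.6 percentage points lower from compound 1 to compound 3 (within the scatter), so this is the first single-place change, which compound 1 and compound 2 could not provide. At this place, the read-out stays within the scatter when the methoxy-bearing ring, with its hydrogen-bond acceptor, gives way to a chlorine-bearing ring with none, so this position accepts this particular change at the one concentration tested. The data available give no measured property that would account for this result.

From the compounds shown here alone, whether the position accepts groups of a different kind, such as an aminophenyl or a carboxyphenyl group, remains open, as does the effect of the same change on the core of compound 2. Going by these compounds, both compound 1 and compound 3 sit at the low end of the read-out at a single concentration, so any difference in potency between them remains open too.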